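The source may report more compounds than this note shows. Statements on the series, on what has been measured and on what is new or still open speak of the compounds shown alone.

In a functional assay on HepG2 cells (Homo sapiens) for inhibition, read by sulforhodamine B assay, with a stated time of 72 h (a lower number here means a stronger inhibitor, a higher number a weaker inhibitor), compound 1 `C[C@H](Nc1nc(N)nc(N)c1C#N)c1nn(-c2cccc(S(C)(=O)=O)c2)c2cc(F)ccc12` gives 19100 nM, and compound 3 `C[C@H](Nc1ncnc2[nH]cnc12)c1nn(-c2cccc(F)c2)c2cc(F)ccc12` gives 32300 nM. Among the measured compounds shown here, these two values lie within the usual scatter of repeated measurements, so compound 1 cannot be told apart from the only other exact number available. Compound 2 `C[C@H](Nc1ncnc2[nH]cnc12)c1nn(-c2cccnc2)c2cc(Cl)ccc12` reads > 40000 nM, which is a limit of the assay. Compound 4 `C[C@H](Nc1nc(N)nc(N)c1C#N)c1nn(-c2cccc(S(C)(=O)=O)c2)c2cc(Cl)ccc12` has not yet been measured. Its structure differs from that of compound 1 by chloro in place of fluoro on an aromatic carbon. For the measured compounds named here, no measured pair shows this swap on its own, so no change beyond the scatter is expected, and the estimated move is a 1.2-fold lower number from compound 1 to compound 4 (0.08 log units; within the scatter). For compound 4, the estimated value is 16000 nM, with an expected range of 8000 nM to 32000 nM.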

Compound 4, half-maximal inhibitory concentration: 1880 nM
Estimate against measurement, compound 4: 8.5-fold (0.93 log units) above; measured number below the stated range.
By their numbers in this assay, from the lowest: compound 4; then compounds 1 and 3 (each within the scatter of the next). At a limit, above all of these: compound 2.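

In this assay, chloro in place of fluoro on this aromatic carbon gives a 10-fold lower number from compound 1 to compound 4 (1.01 log units; beyond the scatter), so exchanging this one atom on the shared core is enough to move the number beyond the scatter. Among the compounds shown here, no earlier pair of compounds isolated this position or any other single change. Nothing shown explains the size of this step.

This single pair leaves open whether the same swap does as much on the other compounds shown. It also leaves open how a bromo, methyl or methoxy group on this carbon would read.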